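The source may report more compounds than this note shows. Statements on the series, on what has been measured and on what is new or still open speak of the compounds shown alone.

Of the compounds shown here, three have been read so far in a functional assay on DU-145 cells (Homo sapiens) for inhibition, read by trypan blue exclusion, with a stated time of 96 h; a lower number here means a stronger inhibitor of growth, a higher number a weaker inhibitor of growth: compound 1 (`Cc1ccc(CS/C(=C/c2c(O)cc(O)cc2O)C(=O)c2ccc(Cl)cc2)cc1`) gives 50000 nM, compound 2 (`O=C(/C(=C\c1ccc(O)cc1)SCc1ccc(Cl)cc1)c1ccc(Br)cc1`) gives 10000 nM and compound 3 (`O=C(/C(=C\c1ccccc1OCc1ccccc1)S(=O)(=O)c1ccc(F)cc1)c1ccc(Cl)cc1`) gives 1000 nM. Compound 2 stands in the middle, with both gaps beyond the scatter. Compound 4 (`O=C(/C(=C\c1ccc(Cl)cc1)SCc1ccc(Cl)cc1)c1ccc(Br)cc1`) departs from compound 2 at one place: chloro in place of hydroxy on an aromatic carbon, para to a large group. Going by the values given here, no measured pair isolates this change, so the expectation is loose. A modest move towards stronger growth inhibition is expected, and the estimated step is a 2.0-fold lower number from compound 2 to compound 4 (0.30 log units; within the scatter). For compound 4 the expected value in this assay is 5000 nM, within an estimated range of 1500 nM to 15000 nM.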

Compound 4, concentration for 50% growth inhibition: 10000 nM
Compound 4: the middle estimate sits 2.0-fold (0.30 log units) below what was measured; the measured number falls inside the stated range.
By their numbers in this assay, from the lowest: compound 3; then compounds 2 and 4 (each within the scatter of the next); then compound 1.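

Going by these compounds alone, replacing 4-hydroxyphenyl with 4-chlorophenyl gives no change at the digits printed from compound 2 to compound 4 (within the scatter) in this assay, and this is the first pair that differs in only one place. In this pair, the hydroxy group, with its hydrogen-bond donor and acceptor, is not required for the reading at this position, and chloro takes its place without separating the two compounds. Nothing available bears on why the two compounds read alike.

As far as these compounds go, whether an amine or a methoxy group at this position would also read alike remains open. From the compounds shown here alone, it is also open whether the same swap would behave this way on the cores of compound 1 or compound 3.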